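The source may hold more compounds than are shown below. What is called first, only, known or untested is meant among the compounds shown, and "the series" means these compounds.

Compound 1, with the structure `Cc1cc(C(=O)NNS(=O)(=O)c2ccccc2F)cc(-c2ccccn2)c1`, is the starting point. Going by the values given here, in a physicochemical assay for solubility, read by nephelometry, in phosphate buffer, measured as kinetic solubility, at pH 6.5 (a lower number here means a less soluble compound, a higher number a more soluble compound), compound 1 gives 12.5 ug/mL, the lowest of the three numbers measured so far. Compound 2, `Cc1cc(-n2nccn2)cc(C(=O)NNS(=O)(=O)c2ccccc2)c1F`, gives 25 ug/mL in this assay, a value that lies within the scatter of repeated measurements relative to compound 1, so the two cannot be told apart. Compound 3, `C=CCOc1ccc(F)c(C(=O)NNS(=O)(=O)c2ccccc2)c1`, gives 50 ug/mL in this assay, and here the gap to compound 1 is beyond the scatter, so compound 3 is genuinely the more soluble of those two.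

Compound 4, `O=C(NNS(=O)(=O)c1ccccc1F)c1cccc(-c2ccccn2)c1`, has not yet been measured. It differs from compound 1 in one place: hydrogen in place of methyl on an aromatic carbon

Among the compounds with values here, no measured pair in this set shows that change, so the expectation rests on compound 1 alone. The step from compound 1 to compound 4 in this assay is estimated to be small and upward, at most at the edge of the scatter: a 1.8-fold higher number from compound 1 to compound 4 (0.25 log units; within the scatter). Compound 4 is therefore expected to reach about 22 ug/mL, with a likely range from 9 ug/mL to 55 ug/mL.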

Compound 4, solubility: 12.5 ug/mL
The estimate for compound 4 lay 1.8-fold (0.25 log units) above the measured number, within the range that was stated.
By their numbers in this assay, from the lowest: compounds 1, 4, 2 and 3 (each within the scatter of the next, the first and the last beyond it).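

Taking the methyl off this aromatic carbon, meta to a pyridin-2-yl group, gives in this assay no change at the digits printed from compound 1 to compound 4 (within the scatter) and so leaves the two compounds indistinguishable. Going by these compounds alone, this is the first pair in the set that differs in only one place, so it offers the first direct reading of a single change, and on the core of compound 1 that reading shows no separation between methyl and hydrogen. Nothing independent is at hand to explain the result.

On these data alone, whether the number would stay put with a different group at this position, such as an amine, a carboxylic acid or a longer alkyl chain, remains open. So does whether the same swap would read alike on another core, such as that of compound 2, which also carries a methyl on an aromatic carbon.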